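Swapping the dichlorophenyl arm for a fluorophenyl arm

This account rests on a few compounds, and the source may have more. Where it says the series, first, only, none or still open, it means among the compounds named here.

Compound 1 `Cc1ccnc(NC(c2ccc3cccnc3c2O)c2c(Cl)cccc2Cl)c1` was tested in a functional assay on U-87MG ATCC cells for inhibition, with U-87 MG (Homo sapiens) as the target, read by MTT assay, with a stated time of 72 h (a lower number here means a stronger inhibitor, a higher number a weaker inhibitor), where compound 1 gives 7200 nM. Compound 2 `Oc1c(C(Nc2ccccn2)c2c(Cl)cccc2Cl)ccc2cccnc12` gives 6900 nM and compound 3 `Oc1c(C(Nc2ccccn2)c2ccccc2Cl)ccc2cccnc12` gives 9400 nM, so compound 1 holds the second highest of the three numbers, all three within the scatter of one another, as shown by a 1.0-fold lower number from compound 1 to compound 2 (0.02 log units; within the scatter). Compound 4 `Cc1ccnc(NC(c2ccccc2F)c2ccc3cccnc3c2O)c1` differs from compound 1 by 2-fluorophenyl in place of 2,6-dichlorophenyl on a saturated chain carbon bound to an aromatic carbon and a nitrogen on an aromatic ring. The closest guide is the loss of a chloro in a 1.4-fold higher number from compound 2 to compound 3 (0.13 log units; within the scatter), which stayed within the scatter, so no step beyond the scatter is expected for compound 4, with at most a slight rise. Compound 4 is therefore expected to give 8500 nM, between 4000 nM and 18000 nM, an estimated step of a 1.2-fold higher number from compound 1 to compound 4 (0.07 log units; within the scatter).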

Compound 4, half-maximal inhibitory concentration: 13100 nM
Compound 4: middle estimate off by 1.5-fold (0.19 log units), on the low side; measured number inside the range.
By their numbers in this assay, from the lowest: compounds 2, 1, 3 and 4 (each within the scatter of the next).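

In this assay, the exchange of the whole arm on a saturated chain carbon bound to an aromatic carbon and a nitrogen on an aromatic ring gives a 1.8-fold higher number from compound 1 to compound 4 (0.26 log units; within the scatter) for 2-fluorophenyl in place of 2,6-dichlorophenyl. The earlier compounds shown here changed only one chloro or one methyl, whereas this change removes both chlorines and brings in a fluorine, and the step still stays within the scatter. Nothing available explains this result. On these data alone, it remains open whether an amine or a carboxylic acid on this arm, or a longer chain in its place, would give a step beyond the scatter.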